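Adding a benzyl group to a weak dimethyl inhibitor

This account rests on a few compounds, and the source may have more. Where it says the series, first, only, none or still open, it means among the compounds named here.

Compound 1 `C=CCn1ncc2c(Br)nc(Cc3ccccc3)n2c1=O`: in a functional assay for inhibition, with Homo sapiens as the target (a lower number here means a stronger inhibitor, a higher number a weaker inhibitor), compound 1 gives > 48000 nM, a limit of the assay.
Compound 2 `C=CCn1ncc2c(C)nc(C)n2c1=O`: in this assay compound 2 gives 73000 nM.

Compound 2 holds the only number shown; the other value is a limit (the limit of > 48000 nM in this assay, at which 1 of the 2 values shown sits). Compound 3 `C=CCn1ncc2c(C)nc(Cc3ccccc3)n2c1=O` differs from compound 2 by phenyl in place of hydrogen on a saturated chain carbon bound to an aromatic carbon. For the measured compounds named here, no measured pair shows this change. Compound 1 also carries the benzyl group and gives only the limit > 48000 nM. The step from compound 2 to compound 3 is expected to be small, a 1.3-fold lower number from compound 2 to compound 3 (0.12 log units; within the scatter), not beyond the usual scatter. Compound 3 is estimated at 55000 nM, within 15000 nM to 200000 nM.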

Compound 3, half-maximal inhibitory concentration: > 48000 nM
Compound 3 was reported as a limit; the forecaster's own chance of this, stated with the estimate: 45%; the middle value is on the limit's open side.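

No step can be read from compound 2 to compound 3 or from compound 1 to compound 3, because compound 3 and compound 1 both give only a limit: the limit of > 48000 nM in this assay, at which 2 of the 3 values shown sit.

As far as these compounds go, how far either phenyl in place of hydrogen or methyl in place of bromo moves the number stays open.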